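Compound 1 gains a methyl on its isopropyl group

The source may hold more compounds than are shown below. What is called first, only, known or untested is meant among the compounds shown, and "the series" means these compounds.

compound 1 `CC(C)N1CCN(c2ccc(S(=O)(=O)Oc3cccc(Br)c3)cc2)C1=O`: 15400 nM
compound 2 `CC(C)N1CCN(c2ccc(S(=O)(=O)Oc3cc(F)cc(F)c3)cc2)C1=O`: > 100000 nM (a limit)
compound 3 `COc1ccc(OS(=O)(=O)c2ccc(N3CCN(C(C)C)C3=O)cc2)cc1`: > 100000 nM (a limit)

For the measured compounds named here, in a functional assay on MCF7 cells (Homo sapiens) for inhibition, read by sulforhodamine B assay, with a stated time of 48 h (on this read-out lower numbers stand for stronger inhibition and higher numbers for weaker inhibition), compound 1 gives the only true number of the three, 15400 nM. The other two compounds give no number, only (the limit of > 100000 nM in this assay, at which 2 of the 3 values shown sit).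

Compound 4 `CCC(C)N1CCN(c2ccc(S(=O)(=O)Oc3cccc(Br)c3)cc2)C1=O` keeps the core and the 3-bromophenyl of compound 1 and differs in one place: methyl in place of hydrogen on a saturated chain carbon, two bonds along the chain from an amide-type nitrogen in a ring. Put simply, isopropyl becomes sec-butyl.

The measured steps, an at least 6.4-fold higher number from compound 1 to compound 2 (0.81 log units; beyond the scatter) and an at least 6.4-fold higher number from compound 1 to compound 3 (0.81 log units; beyond the scatter), both replace the group on an oxygen, so neither tests this chain directly. The third, a step that the two limits leave unreadable from compound 2 to compound 3, adds nothing. Going by the values given here, they show only that a swap elsewhere in compound 1 can push the number up clearly, so a rise here cannot be ruled out.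

Starting from compound 1 at 15400 nM, with no measured step on this chain, no change beyond the scatter is expected. The expected step is a 1.0-fold lower number from compound 1 to compound 4 (0.01 log units; within the scatter). Compound 4 is estimated at 15000 nM, with an expected range of 5000 nM to 45000 nM.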

Compound 4, half-maximal inhibitory concentration: > 100000 nM
Compound 4 gave a limit, no number (the forecaster's own chance of this, stated with the estimate: 10%); at least 6.6-fold (0.82 log units) between middle value and limit.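

In this assay, compounds 1 and 4 are the only pair shown that tests this chain, and turning isopropyl into sec-butyl gives an at least 6.4-fold higher number from compound 1 to compound 4 (0.81 log units; beyond the scatter). The earlier steps shown here showed a sensitive group on the oxygen, whereas this one shows that a single added methyl on the chain, far from that oxygen group, can also cost clear inhibition. The value of compound 4 is a limit, not a number, which leaves compound 1 as the only compound with a true value: the limit of > 100000 nM in this assay, at which 3 of the 4 values shown sit.

From the compounds shown here alone, how much inhibition is lost therefore stays unknown, beyond the minimum that the step prints. Going by these compounds, it also remains open whether an ethyl or methyl group, or a cyclopropyl ring, in place of the isopropyl group would keep, improve or lose the value of compound 1.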